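The source may hold more compounds than are shown below. What is called first, only, known or untested is meant among the compounds shown, and "the series" means these compounds.

Compound 1 `COc1ccc(-c2cnc(NC(=O)c3ccc(Br)cc3)n2C)cc1` reaches only a limit in a toxicity assay on THP-1 cells (Homo sapiens) for inhibition; on this read-out higher numbers stand for lower toxicity in this test and lower numbers for higher toxicity in this test: in this assay compound 1 gives > 100000 nM, a limit of the assay rather than a number. Compound 3 `Cn1c(-c2ccccc2)cnc1NC(=O)c1ccc(Br)cc1` also returns a limit in this assay, > 100000 nM. Compound 2 `Cn1c(-c2ccccc2Cl)cnc1NC(=O)c1ncc[nH]1` likewise gives > 50000 nM, again a limit. Compound 1 therefore stands among values that are all limits, two at the limit of > 100000 nM in this assay, at which 2 of the 3 values shown sit, and one at the limit of > 50000 nM in this assay, at which 1 of the 3 values shown sits. Going by the values given here, the one measured step, a step that the two limits leave unreadable from compound 1 to compound 3, is left unreadable by those limits and concerns a different part of the molecule. Compound 4 `COc1ccc(-c2cnc(NC(=O)c3cccc(F)c3)n2C)cc1` differs from compound 1 by 3-fluorophenyl in place of 4-bromophenyl on a carbonyl carbon. Among the compounds with values here, no measured step touches the 4-bromophenyl, so nothing points to a change beyond the scatter, and compound 4 is expected to sit at a limit once more. Compound 4 is estimated at 120000 nM, between 40000 nM and 400000 nM, the expected step being a step that the limit leaves unreadable from compound 1 to compound 4.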

Compound 4, half-maximal cytotoxic concentration: > 100000 nM
Compound 4: only a limit was reported (the forecaster's own chance of this, stated with the estimate: 85%); the middle value does not contradict the limit.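

Compound 1 and compound 4 both return only a limit in this assay, so the step between them cannot be read. The compounds shown leave open whether 3-fluorophenyl in place of 4-bromophenyl changes the cytotoxic concentration at all.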